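The source may report more compounds than this note shows. Statements on the series, on what has been measured and on what is new or still open speak of the compounds shown alone.

Measured compounds:
- compound 1, `O=c1c2ccccc2[se]n1-c1nc(SCc2ccccc2)n[nH]1`; in an ADME assay on L929 cells (Mus musculus) for antiproliferative activity, read by CCK-8 assay, with a stated time of 48 h (a lower number here means a stronger inhibitor, a higher number a weaker inhibitor), compound 1 gives > 50000 nM, which is a limit of the assay rather than a number.
- compound 2, `CCCCSc1n[nH]c(-n2[se]c3ccccc3c2=O)n1`; in this assay compound 2 gives 30400 nM.
- compound 3, `Cc1ccc(CSc2n[nH]c(-n3[se]c4ccccc4c3=O)n2)cc1`; in this assay compound 3 gives > 50000 nM, again a limit of the assay.

Compound 3 therefore stands at the weak end of what is shown: its value is a limit, and (the limit of > 50000 nM in this assay, at which 2 of the 3 values shown sit). Among the measured compounds shown here, the only readable step reaching it is an at least 1.6-fold higher number from compound 2 to compound 3 (0.21 log units; that floor lies within the scatter). The step that the two limits leave unreadable from compound 1 to compound 3 adds nothing, since both ends are limits.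

Compound 4, `O=c1c2ccccc2[se]n1-c1nc(SCc2ccc([N+](=O)[O-])cc2)n[nH]1`, differs from compound 3 by nitro in place of methyl on an aromatic carbon. For the measured compounds named here, no measured step swaps a methyl for a nitro, so the two steps into compound 3 bear on it only loosely: both show that a benzyl sulfur substituent, with or without a ring methyl, leaves the compound at the limit. Compound 4 is expected to stay there as well, with no step beyond the scatter. Compound 4 is estimated at 50000 nM, in a range from 20000 nM to 120000 nM. That estimate means a step of a number no higher from compound 3 to compound 4 (the limit leaves the size open) is expected.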

Compound 4, half-maximal inhibitory concentration: 7430 nM
Beside the measured number, compound 4's estimate is 6.7-fold (0.83 log units) above it, outside the stated range (below it).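

In this assay, nitro on the aromatic carbon para to a large group gives an at least 6.7-fold lower number from compound 3 to compound 4 (0.82 log units; beyond the scatter), and set against hydrogen at the same place it gives an at least 6.7-fold lower number from compound 1 to compound 4 (0.82 log units; beyond the scatter). Methyl in place of hydrogen there could not be read, so these are the first readable steps showing that a group at this place on the ring can move the number beyond the scatter. Both are only floors, because the starting compounds are limits rather than numbers: the limit of > 50000 nM in this assay, at which 2 of the 4 values shown sit.

The compounds shown leave open whether this is particular to nitro, or whether an amine, a carboxylic acid or a methoxy group at the same place would also lower the number. Also open, going by these compounds, is whether a longer chain between the sulfur and the ring would keep the number this low.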